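Anilino on the sulfonyl sulfur of a shared core

A few compounds are considered here, and "the series" means these few. Any claim that something is new, unique, unknown or untested is made for them only; others in the source may bear on it.

Measured compounds:
compound 1 `CC1(C)CCN1S(=O)(=O)c1cncc(-c2ccn3nc(N)nc3c2)c1` — 50100000 nM
compound 2 `CS(=O)(=O)c1cncc(-c2ccn3nc(N)nc3c2)c1` — 39800000 nM
compound 3 `CC(C)NS(=O)(=O)c1cncc(-c2ccn3nc(N)nc3c2)c1` — 63100000 nM

In an assay on isolated protein for inhibition of phosphatidylinositol 4,5-bisphosphate 3-kinase catalytic subunit beta isoform (Homo sapiens) (on this read-out lower numbers stand for stronger inhibition and higher numbers for weaker inhibition), compound 2 gives the lowest of the three numbers, though each of its neighbours sits within the scatter of it. Compound 4 `Nc1nc2cc(-c3cncc(S(=O)(=O)Nc4ccccc4)c3)ccn2n1` differs from compound 2 by anilino in place of methyl on a sulfonyl sulfur. Three measured steps alter the same sulfonyl sulfur: a 1.3-fold lower number from compound 1 to compound 2 (0.10 log units; within the scatter), a 1.3-fold higher number from compound 1 to compound 3 (0.10 log units; within the scatter) and a 1.6-fold higher number from compound 2 to compound 3 (0.20 log units; within the scatter), none beyond the scatter. Because a 1.6-fold higher number from compound 2 to compound 3 (0.20 log units; within the scatter) already swaps methyl for an amino substituent without a step beyond the scatter, compound 4 is expected to follow suit in this assay, giving an expected step of a 1.1-fold higher number from compound 2 to compound 4 (0.05 log units; within the scatter). Compound 4 is therefore estimated at 45000000 nM, with a range from 15000000 nM to 135000000 nM.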

Compound 4, half-maximal inhibitory concentration: 31600000 nM
Beside the measured number, compound 4's estimate is 1.4-fold (0.15 log units) above it, within the range that was stated.
By their numbers in this assay, from the lowest: compounds 4, 2, 1 and 3 (each within the scatter of the next).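

In this assay, anilino on the sulfonyl sulfur brings the first aromatic ring to this place, yet every step stays within the scatter: a 1.3-fold lower number from compound 2 to compound 4 (0.10 log units; within the scatter), a 1.6-fold lower number from compound 1 to compound 4 (0.20 log units; within the scatter) and a 2.0-fold lower number from compound 3 to compound 4 (0.30 log units; within the scatter), the last being phenyl in place of isopropyl on a sulfonamide nitrogen. All four groups on this sulfur, ring-bearing anilino included, therefore give numbers that cannot be told apart. Nothing available bears on why these numbers stay so close. As far as these compounds go, whether a carboxylic acid or a morpholine ring on this sulfur would give a step beyond the scatter remains open.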